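A few compounds are considered here, and "the series" means these few. Any claim that something is new, unique, unknown or untested is made for them only; others in the source may bear on it.

Measured so far:
- Compound 1 `CCCCCC[C@@H](O)C/C=C\CCCCCCCC(=O)N[C@@H](C)c1ccccc1`: 9.7 ug/mL
- Compound 2 `CCCCC/C=C\C/C=C\CCCCCCCC(=O)N1CCCCC1`: 4.2 ug/mL
- Compound 3 `CCCCCCCCCCCCCCCC(=O)N1CCOCC1`: 28.9 ug/mL

In an ADME assay on HaCaT cells (Homo sapiens) for cytotoxicity, read by sulforhodamine B assay, with a stated time of 48 h (on this read-out higher numbers stand for lower toxicity in this test and lower numbers for higher toxicity in this test), compound 1 gives 9.7 ug/mL, the middle of the three numbers. Compound 2 lies lower at 4.2 ug/mL and compound 3 lies higher at 28.9 ug/mL, and both gaps from compound 1 go beyond the usual scatter.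

The next compound to be tested, compound 4 `CCCCCC[C@@H](O)C/C=C\CCCCCCCC(=O)N1CCOCC1`, keeps the core of compound 1 and differs in one place: morpholin-4-yl in place of (1-phenylethyl)amino on a carbonyl carbon. In words, morpholin-4-yl takes the place of (1-phenylethyl)amino on a carbonyl carbon.

Among the compounds with values here, no measured pair shows this change alone, so any forecast is rough. Within the data shown here, the only hint is compound 3, which also carries morpholin-4-yl and gives 28.9 ug/mL, although the rest of its structure differs from compound 4. A modest upward move in this assay therefore seems likely, and it may not clear the scatter. The expected change is a 1.6-fold higher number from compound 1 to compound 4 (0.22 log units; within the scatter). For compound 4 the estimated value is 16 ug/mL, with an expected range of 7 ug/mL to 38 ug/mL.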

Compound 4, concentration lethal to 50% of the cells: 41.3 ug/mL
The estimate for compound 4 lay 2.6-fold (0.41 log units) below the measured number, outside the stated range (above it).
By their numbers in this assay, from the lowest: compound 2; then compound 1; then compounds 3 and 4 (each within the scatter of the next).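

On the carbonyl carbon of the core of compound 1, morpholin-4-yl in place of (1-phenylethyl)amino gives a 4.3-fold higher number from compound 1 to compound 4 (0.63 log units; beyond the scatter) in this assay, so this single position can move toxicity in this test by more than the usual scatter. Within the data shown here, no earlier pair differed in one place alone, so this is the first direct reading of a change at this position. The change removes an aromatic ring, the amide hydrogen and a defined stereocentre together, and no measurement here explains the shift or separates these parts.

Which of these parts matters remains open. A dimethylamino or 4-methylpiperazin-1-yl group on the same carbonyl carbon would show whether the higher number belongs to morpholin-4-yl itself or appears with other groups too.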